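Chloro Placement on Two Anilide Cores in a Cell Growth Assay

This account rests on a few compounds, and the source may have more. Where it says the series, first, only, none or still open, it means among the compounds named here.

Compound 1 `O=C(CCCCC(S)CCS)Nc1ccccc1` gives 11.6% in a functional assay on KB cells (Homo sapiens) for inhibition, read by MTT assay, with a stated time of 24 h, tested at 1 ug/mL; on this read-out higher numbers stand for more inhibition of growth at the one concentration tested and lower numbers for less inhibition of growth.
Compound 2 `O=C(CCCCC(S)CCS)Nc1ccc(Cl)cc1` gives 13.4% in this assay.
Compound 3 `CC(=O)SCCC(CCCCC(=O)Nc1ccccc1)SC(C)=O` gives 1.68% in this assay.

Compound 1 and compound 2 share a core and differ by chloro in place of hydrogen on an aromatic carbon; the step of a number 1.8 percentage points higher from compound 1 to compound 2 (within the scatter) is the result. Compound 3 carries a different core, and the difference between the two cores is not broken down here; its value in this assay lies within the scatter of compound 1 and beyond the scatter of compound 2.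

Compound 4 `CC(=O)SCCC(CCCCC(=O)Nc1ccccc1Cl)SC(C)=O` has not been measured. It differs from compound 3 by chloro in place of hydrogen on an aromatic carbon. This is the same kind of change as between compound 1 and compound 2, but not the same: in compound 2 the chloro sits para to a large group, whereas in compound 4 it sits ortho to a large group. For the measured compounds named here, the one measured instance of this kind of change, a number 1.8 percentage points higher from compound 1 to compound 2 (within the scatter), stayed within the scatter, so compound 4 is expected to move only slightly, a number 1.8 percentage points higher from compound 3 to compound 4 (within the scatter), relative to compound 3. The estimate for compound 4 in this assay is 3.5%, expected to fall between -5% and 13%.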

Compound 4, percent growth inhibition at one concentration: 8.21%
Beside the measured number, compound 4's estimate is 4.7 percentage points below it; low and high end bracket the measured number.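

In this assay, chloro in place of hydrogen on an aromatic carbon, here ortho to a large group, gives a number 6.5 percentage points higher from compound 3 to compound 4 (within the scatter). Set beside the earlier step, the same kind of change on the two cores gives steps that cannot be told apart: the same change on two cores in this assay, a number 1.8 percentage points higher (within the scatter) from compound 1 to compound 2 and a number 6.5 percentage points higher (within the scatter) from compound 3 to compound 4, 4.7 percentage points apart, within the scatter of two such steps. This agrees with the change carrying over from one core to the other, but it does not show that chloro has any effect on either core, since neither step lies beyond the scatter, and it cannot separate the influence of the core from that of where the chloro sits, which differs between compound 2 and compound 4.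

The compounds shown leave open what chloro would do at one and the same place on both cores, and whether a 2-chlorophenyl amide on the core of compound 1 would behave like compound 4. They also leave open how a methoxy group or a nitrile on the ring, or a longer chain, would read in this assay.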